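Pyrazine Hydrazones: Replacing a Hydroxy Group with Dimethylamino

A few compounds are considered here, and "the series" means these few. Any claim that something is new, unique, unknown or untested is made for them only; others in the source may bear on it.

Compound 1, `O=C(N/N=C/c1ccc(Cl)cc1)c1cnccn1`: 64%
Compound 2, `COc1ccc(/C=N/NC(=O)c2cnccn2)cc1`: 55%
Compound 3, `O=C(N/N=C/c1ccc(O)cc1)c1cnccn1`: 81%

In an ADME assay on J774 cells (Mus musculus) for cytotoxicity, read by MTT assay, with a stated time of 48 h, tested at 100 ug/mL (a higher number here means a weaker effect of the compound at the concentration tested, a lower number a stronger effect), compound 3 gives 81%, the highest of the three numbers. The step of a number 17 percentage points higher from compound 1 to compound 3 (beyond the scatter) and the step of a number 26 percentage points higher from compound 2 to compound 3 (beyond the scatter) both lie beyond the scatter, so compound 3 stands clearly above the other two, whereas the step of a number 9 percentage points lower from compound 1 to compound 2 (within the scatter) lies within it, so compounds 1 and 2 cannot be ordered against each other.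

Compound 4, `CN(C)c1ccc(/C=N/NC(=O)c2cnccn2)cc1`, differs from compound 3 in one place: dimethylamino in place of hydroxy on an aromatic carbon. Among the compounds with values here, no measured step involves a dimethylamino group, so the bearing of the known steps is indirect. Both steps that end at compound 3 rise on arriving at the hydroxy group, and both were modest in size. Removing that group again is expected to undo part of that rise. Compound 4 is therefore estimated at 62%, with a range from 45% to 80%. The expected step is a number 19 percentage points lower from compound 3 to compound 4 (beyond the scatter), a modest fall rather than none, though the uncertainty is wide.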

Compound 4, a percentage reported as activity, at one concentration (the size of the read-out at that concentration, not a potency): 87%
The estimate for compound 4 lay 25 percentage points below the measured number; measured number outside the range, above it.
By their numbers in this assay, from the lowest: compounds 2 and 1 (each within the scatter of the next); then compounds 3 and 4 (each within the scatter of the next).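

In this assay, the step of a number 6 percentage points higher from compound 3 to compound 4 (within the scatter) shows that, at this place para to a large group, the high number does not depend on the hydroxy group: dimethylamino, with 0 hydrogen-bond donors and 3 heavy atoms, cannot be told apart from it. The steps of a number 32 percentage points higher from compound 2 to compound 4 (beyond the scatter) and a number 23 percentage points higher from compound 1 to compound 4 (beyond the scatter) set dimethylamino clear of both methoxy and chloro, so that the two groups bearing the high numbers stand apart from the two bearing the lower numbers. Nothing measured here explains this difference between the groups.

The compounds shown leave open whether a primary amine or a carboxylic acid at this place would also give a number in the range of compound 3 and compound 4. They also leave open whether a larger amine, such as diethylamino or a piperidine, would do the same.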